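This account rests on a few compounds, and the source may have more. Where it says the series, first, only, none or still open, it means among the compounds named here.

Measured compounds in a functional assay on HEK293 cells for antagonist activity at Oxytocin receptor (Homo sapiens), read by calcium flux, with a stated time of 10 min, in the presence of a further agent that is not named here; a lower number here means a stronger inhibitor, a higher number a weaker inhibitor:
compound 1 `COc1ccc(-n2c(COCCF)nnc2N2C[C@@H]3C[C@]3(c3ccc(F)cc3Cl)C2)cn1` gives 44 nM
compound 2 `COc1ccc(-n2c(COC3CCOCC3)nnc2N2C[C@@H]3C[C@]3(c3ccc(F)cc3Cl)C2)cn1` gives 826 nM
compound 3 `COc1ccc(-n2c(CO[C@@H]3CCOC3)nnc2N2C[C@@H]3C[C@]3(c3ccc(F)cc3Cl)C2)cn1` gives 223 nM

Compound 3 sits second highest of the three numbers in this assay: a 3.7-fold lower number from compound 2 to compound 3 (0.57 log units; beyond the scatter) places it under compound 2, and a 5.1-fold higher number from compound 1 to compound 3 (0.70 log units; beyond the scatter) places it above compound 1. For the measured compounds named here, the whole series so far varies only the group on the ether oxygen, and the step of a 19-fold higher number from compound 1 to compound 2 (1.27 log units; beyond the scatter) is the largest of the set.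

Compound 4 `COc1ccc(-n2c(C3CC3)nnc2N2C[C@@H]3C[C@]3(c3ccc(F)cc3Cl)C2)cn1` is the next compound: cyclopropyl in place of ((oxolan-3-yl)oxy)methyl on an aromatic carbon. Going by the values given here, no measured step changes the group in this way; the three steps all keep the ether and swap what sits on its oxygen. What they show is that the compound with the 2-fluoroethyl group, compound 1, carries the lowest number, and that each ring on the oxygen raised it. Cyclopropyl is a different kind of change, so the expectation is loosely held. Compound 4 is expected to land at 70 nM, with a range of 15 nM to 350 nM, the step of a 3.2-fold lower number from compound 3 to compound 4 (0.50 log units; beyond the scatter) being the estimate.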

Compound 4, half-maximal inhibitory concentration: 433 nM
Estimate against measurement, compound 4: 6.2-fold (0.79 log units) below, and the stated range ends below it.
By their numbers in this assay, from the lowest: compound 1; then compounds 3, 4 and 2 (each within the scatter of the next, the first and the last beyond it).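

In this assay, cyclopropyl on the aromatic carbon of the five-membered aromatic ring takes the place of the whole ether side chain and reads level with both ring ethers: a 1.9-fold higher number from compound 3 to compound 4 (0.29 log units; within the scatter) and a 1.9-fold lower number from compound 2 to compound 4 (0.28 log units; within the scatter). Only the (2-fluoroethoxy)methyl group stands apart, with a 9.8-fold higher number from compound 1 to compound 4 (0.99 log units; beyond the scatter), so among these four compounds an ether oxygen at this position does not by itself set the number, and the open fluorinated chain of compound 1 is the one exception. Nothing measured here accounts for compound 1 standing apart or for cyclopropyl matching the ring ethers.

Open, from the compounds shown here alone, is whether the fluorine or the open chain sets compound 1 apart, a question a plain ethoxymethyl group would address. Also open, going by these compounds, is how an aminomethyl group or a carboxylic acid would read at this position.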